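The compounds below may be only part of what the source reports. "The series", "measured", "known", "first", "only" and "open" are said of these compounds alone.

The study compares three measured compounds with one still to be tested. Compound 1 `CC1=CC[C@H](C(C)(C)NC(=S)N/N=C/c2ccc(O)cc2)CC1`, compound 2 `COc1cc(/C=N/NC(=S)NC(C)(C)[C@H]2CC=C(C)CC2)ccc1O` and compound 3 `CC1=CC[C@H](C(C)(C)NC(=S)N/N=C(\C)c2ccccc2)CC1` were run in a functional assay on NCI-H460 cells (Homo sapiens) for inhibition, read by sulforhodamine B assay, with a stated time of 48 h; a higher number here means a weaker inhibitor of growth, a lower number a stronger inhibitor of growth. In this assay compound 1 reaches only the limit > 100000 nM. Compound 2 likewise gives only the limit > 100000 nM. Compound 3 too stops at the limit > 100000 nM. The change from compound 1 to compound 2, (methoxy in place of hydrogen on an aromatic carbon), thus yields a step that the two limits leave unreadable from compound 1 to compound 2. Compound 4 `COc1ccc(/C(C)=N/NC(=S)NC(C)(C)[C@H]2CC=C(C)CC2)cc1` arises from compound 3 by the same kind of change, (methoxy in place of hydrogen on an aromatic carbon), though here it sits para to a large group rather than ortho to a hydroxy group and meta to a large group; the difference between the two cores is not broken down here. Because (the limit of > 100000 nM in this assay, at which 3 of the 3 values shown sit), the step is expected to be a number no higher from compound 3 to compound 4 (the limit leaves the size open). Compound 4 is therefore estimated at 100000 nM, within a range from 40000 nM to 250000 nM.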

Compound 4, concentration for total growth inhibition: > 100000 nM
Compound 4: no number, only a limit (the forecaster's own chance of this, stated with the estimate: 85%); the middle value sits exactly at the limit.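

No step can be read from compound 3 to compound 4, since both stop at a limit rather than a number: the limit of > 100000 nM in this assay, at which 4 of the 4 values shown sit. The compounds shown leave open how strongly any of them inhibits growth in this assay and whether methoxy in place of hydrogen changes that.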